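This account rests on a few compounds, and the source may have more. Where it says the series, first, only, none or still open, it means among the compounds named here.

Measured so far:
- compound 1 `CCOc1ccccc1-c1ccc(-c2nc3cnccc3cc2C#N)cc1`: 3.8
- compound 2 `N#Cc1c(-c2ccc(Br)cc2)nc2cnccc2c1NCC(N)=O`: 1.9
- compound 3 `CC[C@@H](Nc1c(C#N)c(-c2ccc(-c3ccccc3NC)cc2)nc2cnccc12)C(N)=O`: 2.5

In a physicochemical assay for lipophilicity, read by HPLC, at pH 7.5 (on this read-out lower numbers stand for lower lipophilicity and higher numbers for higher lipophilicity), compound 1 gives 3.8, the highest of the three numbers; compound 3 lies beyond the scatter below it, and compound 2 further still. Compound 4 `CCOc1ccccc1-c1ccc(-c2nc3cnccc3c(N[C@@H]3CCOC3=O)c2C#N)cc1` is not yet measured in this assay. It differs from compound 1 in one place: (2-oxooxolan-3-yl)amino in place of hydrogen on an aromatic carbon. Within the data shown here, no step between measured compounds that differ in a single place is available, so the size of this move cannot be read directly from the data. A fall beyond the scatter is nonetheless expected, because compound 3 gives 2.5 and compound 2 gives 1.9 with their own structures. The step expected is a number 0.60 log units lower from compound 1 to compound 4 (beyond the scatter). Compound 4 is estimated at 3.2, within 2.6 to 3.8.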

Compound 4, distribution coefficient: 2.7
Compound 4: the middle estimate sits 0.50 log units above what was measured; measured number inside the range.
By their numbers in this assay, from the lowest: compound 2; then compounds 3 and 4 (each within the scatter of the next); then compound 1.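

In this assay, (2-oxooxolan-3-yl)amino in place of hydrogen on the aromatic carbon ortho to a cyano group gives a number 1.10 log units lower from compound 1 to compound 4 (beyond the scatter) as the only single-place step shown, and a large one. It shows that the read-out responds strongly to a change at this position, opposite the ring nitrogen. Nothing at hand accounts for the size of this step.

As far as these compounds go, it remains open whether the amino link or the five-membered ring carries the step. A plain methylamino group, a hydroxyl group or a carboxylic acid at this position could separate those contributions and show how far the step depends on the group.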